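Aryl sulfonamide variation: from compound 3 to compound 4

The compounds below may be only part of what the source reports. "The series", "measured", "known", "first", "only" and "open" are said of these compounds alone.

Measured so far in an assay on brain for displacement of a labelled ligand from 5-hydroxytryptamine receptor 4 (Cavia porcellus), with a stated time of 30 min, in the presence of a further agent that is not named here; a lower number here means a stronger inhibitor, a higher number a weaker inhibitor:
compound 1 `COc1ccc(S(=O)(=O)NCCN2CCC(CCC(=O)c3cc(Cl)c(N)cc3OC)CC2)cc1Cl` gives 22.5 nM
compound 2 `COc1ccc(S(=O)(=O)NCCCN2CCC(CCC(=O)c3cc(Cl)c(N)cc3OC)CC2)cc1` gives 26 nM
compound 3 `COc1cc(N)c(Cl)cc1C(=O)CCC1CCN(CCNS(=O)(=O)c2cc(Br)ccc2Br)CC1` gives 16.3 nM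

Compound 3 has the lowest of the three numbers in this assay, but the gaps to the other two are small: compound 1 is nearest, compound 2 furthest, and both differences fall within the usual scatter, so the three are not separated.

The next compound, compound 4 `COc1ccc(S(=O)(=O)NCCN2CCC(CCC(=O)c3cc(Cl)c(N)cc3OC)CC2)cc1Br`, differs from compound 3 at the sulfonyl sulfur only: 3-bromo-4-methoxyphenyl in place of 2,5-dibromophenyl on a sulfonyl sulfur.

For the measured compounds named here, one measured step bears on this position. Going from compound 1 to compound 3, the aryl group on the sulfonyl sulfur was changed from 3-chloro-4-methoxyphenyl to 2,5-dibromophenyl, and this gave a 1.4-fold lower number from compound 1 to compound 3 (0.14 log units; within the scatter). The aryl group entering in compound 4 resembles that of compound 1 far more than that of compound 3, so the reverse of that step is the relevant guide, and it was within the scatter. No step beyond the scatter is therefore expected in this assay.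

For compound 4 the estimated step is a 1.3-fold higher number from compound 3 to compound 4 (0.11 log units; within the scatter). The expected value for compound 4 is 21 nM, with a range from 10 nM to 45 nM.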

Compound 4, inhibition constant: 24.3 nM
Estimate against measurement, compound 4: 1.2-fold (0.06 log units) below; low and high end bracket the measured number.
By their numbers in this assay, from the lowest: compounds 3, 1, 4 and 2 (each within the scatter of the next).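

In this assay, the exchange of 2,5-dibromophenyl for 3-bromo-4-methoxyphenyl on the sulfonyl sulfur gives a 1.5-fold higher number from compound 3 to compound 4 (0.17 log units; within the scatter), so these two aryl groups are not separated, just as the earlier exchange of aryl groups, a 1.4-fold lower number from compound 1 to compound 3 (0.14 log units; within the scatter), separated nothing. New here is a single-halogen comparison within the methoxy-bearing aryl group: bromo in place of chloro on an aromatic carbon gives a 1.1-fold higher number from compound 1 to compound 4 (0.03 log units; within the scatter), so these two halogens are not separated in this aryl setting, and the three aryl groups in compound 1, compound 3 and compound 4 all lie within the scatter of one another on this core. No measurement shown here gives a reason for this flat response.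

Still open, going by these compounds, is whether the flat response extends to aryl groups carrying an amine or a carboxylic acid, or to a non-aromatic group such as cyclohexyl on the sulfonyl sulfur, since all three aryl groups compared here carry halogen. The effect of a longer chain between the sulfonamide nitrogen and the ring nitrogen also remains unresolved, as compound 2 differs from each of the other compounds in more than one place.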